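Amide variation on the shared core: toward compound 4

A few compounds are considered here, and "the series" means these few. Any claim that something is new, unique, unknown or untested is made for them only; others in the source may bear on it.

Measured compounds:
Compound 1, `CCN(CC)S(=O)(=O)c1ccc(S(=O)(=O)N2CCC[C@@H](C(=O)N3CCC(COC)CC3)C2)cc1`, gives 50 nM in a functional assay on MIA PaCa-2 cells (Homo sapiens) for inhibition, read by MTT assay, with a stated time of 3 days; a higher number here means a weaker inhibitor, a lower number a stronger inhibitor.
Compound 2, `CCN(CC)S(=O)(=O)c1ccc(S(=O)(=O)N2CCC[C@@H](C(=O)N[C@H]3CC[C@@H](OC)CC3)C2)cc1`, gives 590 nM in this assay.
Compound 3, `CCN(CC)S(=O)(=O)c1ccc(S(=O)(=O)N2CCC[C@@H](C(=O)N3CCC(F)(F)CC3)C2)cc1`, gives 19 nM in this assay.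

Compound 3 stands lowest of the three numbers. Its nearest neighbour is reached by the modest step of a 2.6-fold lower number from compound 1 to compound 3 (0.42 log units; beyond the scatter); the furthest by the large step of a 31-fold lower number from compound 2 to compound 3 (1.49 log units; beyond the scatter). The large steps of a 12-fold higher number from compound 1 to compound 2 (1.07 log units; beyond the scatter) and a 31-fold lower number from compound 2 to compound 3 (1.49 log units; beyond the scatter) both exchange a piperidine for an open cyclohexylamine on the carbonyl carbon, whereas the modest step of a 2.6-fold lower number from compound 1 to compound 3 (0.42 log units; beyond the scatter) exchanges one piperidine for another.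

Compound 4, `CCN(CC)S(=O)(=O)c1ccc(S(=O)(=O)N2CCC[C@@H](C(=O)N3CCC(C(F)F)CC3)C2)cc1`, differs from compound 3 by 4-(difluoromethyl)piperidin-1-yl in place of 4,4-difluoropiperidin-1-yl on a carbonyl carbon. This is again a piperidine-for-piperidine exchange on the carbonyl carbon, so only the modest step of a 2.6-fold lower number from compound 1 to compound 3 (0.42 log units; beyond the scatter) bears on it directly; compound 1, carrying a 4-(methoxymethyl)piperidin-1-yl, sits close to compound 3. A small step is therefore expected in this assay, if anything toward a higher number, a 1.6-fold higher number from compound 3 to compound 4 (0.20 log units; within the scatter), though it may well lie within the scatter. Compound 4 is estimated at 30 nM, with a range from 12 nM to 75 nM.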

Compound 4, half-maximal inhibitory concentration: 140 nM
Estimate against measurement, compound 4: 4.7-fold (0.67 log units) below, and the stated range ends below it.
By their numbers in this assay, from the lowest: compound 3; then compound 1; then compound 4; then compound 2.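

In this assay, exchanging one piperidine for another on the carbonyl carbon is not necessarily a small change: 4-(difluoromethyl)piperidin-1-yl in place of 4,4-difluoropiperidin-1-yl gives a 7.4-fold higher number from compound 3 to compound 4 (0.87 log units; beyond the scatter), so this position distinguishes closely related fluorinated piperidines. Difluoromethyl in place of methoxymethyl on a saturated ring carbon gives a 2.8-fold higher number from compound 1 to compound 4 (0.45 log units; beyond the scatter), which places compound 4 behind both other piperidine amides. The piperidine amide compound 4 still keeps a lower number than the open amide, with a 4.2-fold lower number from compound 2 to compound 4 (0.62 log units; beyond the scatter), and among the four compounds none goes against this order of piperidine amides below the (4-methoxycyclohexyl)amino amide.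

No measurement at hand accounts for the size of these steps. Open, on these data alone, is whether 4-fluoropiperidin-1-yl or 4-(trifluoromethyl)piperidin-1-yl on the carbonyl carbon would stand nearer compound 3 or compound 4.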